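Compound 4: 1H-imidazol-5-yl in place of propyl

The compounds below may be only part of what the source reports. "The series", "measured", "known", "first", "only" and "open" are said of these compounds alone.

Measured in a toxicity assay on THP-1 cells (Homo sapiens) for inhibition (a lower number here means that less compound is tolerated, a higher number that more compound is tolerated), all three results being limits:
Compound 1 `COc1ccc(-c2cnc(NC(=O)c3ccccc3O)n2C)cc1`: > 100000 nM
Compound 2 `COc1ccc(-c2cnc(NC(=O)C3CCNCC3)n2C)cc1`: > 100000 nM
Compound 3 `CCCC(=O)Nc1ncc(-c2ccc(OC)cc2)n1C`: > 100000 nM

Compound 3 gives > 100000 nM, which is a limit and not a number. It shares this position with the other two compounds, so the whole series stands at the limit of > 100000 nM in this assay, at which 3 of the 3 values shown sit.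

Compound 4 `COc1ccc(-c2cnc(NC(=O)c3cnc[nH]3)n2C)cc1` carries 1H-imidazol-5-yl in place of propyl on a carbonyl carbon, (1H-imidazol-5-yl in place of propyl on a carbonyl carbon).

For the measured compounds named here, three measured steps bear on this change, all made on that same carbonyl carbon: a step that the two limits leave unreadable from compound 1 to compound 2, a step that the two limits leave unreadable from compound 1 to compound 3 and a step that the two limits leave unreadable from compound 2 to compound 3. None of them has a readable size. Going by the values given here, with 2-hydroxyphenyl, piperidin-4-yl or propyl on that carbon, no compound has yet given a value short of the limit. No step beyond the scatter is therefore expected in this assay, although limits alone cannot rule one out. The step expected is a number no higher from compound 3 to compound 4 (the limit leaves the size open). Compound 4 is estimated at 100000 nM, with an expected range from 40000 nM to 200000 nM.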

Compound 4, half-maximal cytotoxic concentration: > 100000 nM
Compound 4: a limit, no number (the forecaster's own chance of this, stated with the estimate: 85%); the middle value lies on the limit itself.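

In this assay compound 4 gives > 100000 nM, which is a limit and not a number, so its steps from compound 1, compound 2 and compound 3 cannot be read. All four compounds now stand together: the limit of > 100000 nM in this assay, at which 4 of the 4 values shown sit.

The compounds shown leave open whether any group on that carbonyl carbon changes the concentration tolerated, and by how much.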